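A few compounds are considered here, and "the series" means these few. Any claim that something is new, unique, unknown or untested is made for them only; others in the source may bear on it.

Series notes: in an ADME assay on BHK-21 cells (Mesocricetus auratus) for cytotoxicity, read by MTT assay, with a stated time of 72 h (on this read-out lower numbers stand for higher toxicity in this test and higher numbers for lower toxicity in this test), compound 1 (`NS(=O)(=O)c1ccc(N2N=C(c3ccc(OCc4ccccc4)cc3)CC2c2ccccc2)cc1`) gives 80000 nM and compound 2 (`NS(=O)(=O)c1ccc(N2N=C(c3ccc(OCc4ccccc4)cc3)CC2c2ccccc2Cl)cc1`) gives 12000 nM as the lower of the two numbers. Compound 3 (`Cc1ccc(C2CC(c3ccc(OCc4ccccc4)cc3)=NN2c2ccc(S(N)(=O)=O)cc2)cc1`) has 4-methylphenyl in place of 2-chlorophenyl on a saturated ring carbon, and 4-methylphenyl in place of 2-chlorophenyl on a saturated ring carbon gives the count. For the measured compounds named here, the one measured step bearing on this is a 6.7-fold lower number from compound 1 to compound 2 (0.82 log units; beyond the scatter) with chloro in place of hydrogen on an aromatic carbon, a modest step. As far as these compounds go, compound 3 carries no chloro, but methyl is untested here, so only part of that step should reverse. The expected change is a 2.9-fold higher number from compound 2 to compound 3 (0.46 log units; beyond the scatter) in this assay as a rise smaller than the chloro step. Compound 3 is estimated at 35000 nM with an expected range of 12000 nM to 90000 nM for this measurement.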

Compound 3, half-maximal cytotoxic concentration: 32000 nM
Compound 3: the middle estimate sits 1.1-fold (0.04 log units) above what was measured; the range from low to high includes it.
By their numbers in this assay, from the lowest: compound 2; then compound 3; then compound 1.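

In this assay the lower number is not confined to chloro: methyl also gives a 2.5-fold lower number from compound 1 to compound 3 (0.40 log units; beyond the scatter) and so stays beyond the scatter. The change to 4-methylphenyl from 2-chlorophenyl gives a 2.7-fold higher number from compound 2 to compound 3 (0.43 log units; beyond the scatter) and leaves compound 3 between the other two, but the substituent and its place on the phenyl change together. Nothing available explains either step.

Still open, as far as these compounds go, is how chloro and methyl compare at one shared place on this phenyl. Also open, from the compounds shown here alone, is how an amine or a carboxylic acid on that phenyl would read.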